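Chloro to nitro on the aryl ring of a thiosemicarbazone

This account rests on a few compounds, and the source may have more. Where it says the series, first, only, none or still open, it means among the compounds named here.

Measured so far:
compound 1, `CC1=CC[C@H](C(C)(C)NC(=S)N/N=C/c2ccccc2Cl)CC1`, > 100000 nM;
compound 2, `CC1=CC[C@H](C(C)(C)NC(=S)N/N=C/c2cccc(Cl)c2)CC1`, 53000 nM;
compound 3, `CC1=CC[C@H](C(C)(C)NC(=S)N/N=C/c2ccccc2[N+](=O)[O-])CC1`, 70800 nM.

In a functional assay on HT-29 cells (Homo sapiens) for inhibition, read by sulforhodamine B assay, with a stated time of 48 h (a higher number here means a weaker inhibitor of growth, a lower number a stronger inhibitor of growth), compound 1 gives only a limit, > 100000 nM, not a number. The step of an at least 1.8-fold lower number from compound 1 to compound 2 (0.27 log units; that floor lies within the scatter) is therefore a floor, because compound 1 sits at the limit of > 100000 nM in this assay, at which 1 of the 3 values shown sits; the two differ by 3-chlorophenyl in place of 2-chlorophenyl on a carbon with a double bond to nitrogen. The step of an at least 1.4-fold lower number from compound 1 to compound 3 (0.14 log units; that floor lies within the scatter) is a floor for the same reason and comes from nitro in place of chloro on an aromatic carbon. Compound 4, `CC1=CC[C@H](C(C)(C)NC(=S)N/N=C/c2cccc([N+](=O)[O-])c2)CC1`, is not yet measured; it differs from compound 2 by nitro in place of chloro on an aromatic carbon. The place lines differ in one word, ortho against meta to the large group, so this is the same kind of change, not the same. Resting on compound 3 at 70800 nM, a similar small step is expected, a 1.1-fold lower number from compound 2 to compound 4 (0.03 log units; within the scatter). Compound 4 is thus estimated at 50000 nM, within 20000 nM to 100000 nM.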

Compound 4, concentration for total growth inhibition: 21900 nM
The estimate for compound 4 lay 2.3-fold (0.36 log units) above the measured number, within the range that was stated.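

In this assay, nitro in place of chloro on an aromatic carbon gives a 2.4-fold lower number from compound 2 to compound 4 (0.38 log units; beyond the scatter), so on the core of compound 2 this change yields a stronger inhibitor of growth. This does not show that the change carries over from one core to the other at the same size, and the two steps cannot be told apart: the same change on two cores in this assay, an at least 1.4-fold lower number (0.14 log units; that floor lies within the scatter) from compound 1 to compound 3 and a 2.4-fold lower number (0.38 log units; beyond the scatter) from compound 2 to compound 4; the limit leaves it open whether they differ Compound 1 gives only a limit, not a number: the limit of > 100000 nM in this assay, at which 1 of the 4 values shown sits.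

The compounds shown compare only chloro and nitro, so it stays open how an amine or a carboxylic acid on the aromatic ring would behave. They also leave open whether the step would hold on a third core.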